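A few compounds are considered here, and "the series" means these few. Any claim that something is new, unique, unknown or untested is made for them only; others in the source may bear on it.

Measured compounds:
Compound 1 `CN1CCN(c2ccc(Nc3ncc4c(n3)N(C3CCCC3)CC(=O)N4)cc2)CC1` — 21300 nM
Compound 2 `CN1CCN(c2ccc(Nc3ncc4c(n3)N(C3CCCC3)CC(=O)N4C)cc2)CC1` — 6750 nM

Compound 1 and compound 2 share one core and differ at a single point. In a functional assay on HeLa cells (Homo sapiens) for inhibition, read by MTT assay, with a stated time of 48 h (on this read-out lower numbers stand for stronger inhibition and higher numbers for weaker inhibition), compound 1 gives 21300 nM, while compound 2 gives 6750 nM. Among the compounds with values here, the only step measured so far, a 3.2-fold lower number from compound 1 to compound 2 (0.50 log units; beyond the scatter), comes from placing a methyl in place of hydrogen on an amide-type nitrogen in a ring. On these two numbers compound 2 stands as the lower of the pair, and its nearest neighbour is compound 1 at a higher number beyond the scatter.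

Compound 3 `CC1CCN(c2ccc(Nc3ncc4c(n3)N(C3CCCC3)CC(=O)N4C)cc2)CC1` keeps the methylated ring nitrogen of compound 2 and alters the other end of the molecule: 4-methylpiperidin-1-yl in place of 4-methylpiperazin-1-yl on an aromatic carbon. Within the data shown here, the one measured step concerns a different site, so no measured step bears on this change. With nothing to lean on, the expectation for compound 3 is a number close to that of compound 2, a step of a 1.2-fold higher number from compound 2 to compound 3 (0.07 log units; within the scatter), that is, none beyond the scatter. Compound 3 is therefore estimated at 8000 nM in this assay, within a range from 2500 nM to 25000 nM.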

Compound 3, half-maximal inhibitory concentration: > 30000 nM
Compound 3: only a limit was reported; the forecaster's own chance of this, stated with the estimate: 10%; middle value at least 3.7-fold (0.57 log units) from the limit.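

In this assay, the change at the far end of the molecule gives an at least 4.4-fold higher number from compound 2 to compound 3 (0.64 log units; beyond the scatter), so this position on the aromatic ring, para to a large group, matters for the read-out, whereas the earlier pair spoke only to the amide-type ring nitrogen. The swap is a small one: both groups have 7 heavy atoms and one six-membered non-aromatic ring, and the difference is a carbon in place of a ring nitrogen, yet inhibition in this assay weakens beyond the scatter, in the opposite direction to the earlier methyl step. The reading for compound 3 is only a limit, so the step has a lower bound and no known full size: the limit of > 30000 nM in this assay, at which 1 of the 3 values shown sits.

With one pair at this position, the compounds shown leave open whether the ring nitrogen itself is what counts, or whether a morpholine ring, with oxygen at that spot, or a piperazine with hydrogen in place of the methyl would hold the number of compound 2. They also leave open whether the piperidine swap would act the same way on the core of compound 1, which has the amide hydrogen.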